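Methoxy in Place of Methyl: What to Expect

The source may hold more compounds than are shown below. What is called first, only, known or untested is meant among the compounds shown, and "the series" means these compounds.

Of the compounds shown here, two have been measured in a functional assay on P388 cells (Mus musculus); on this read-out lower numbers stand for stronger inhibition and higher numbers for weaker inhibition. Compound 1 `COc1ccc(/C=C/C(=O)Oc2ccc(/C=C3\CCCCC3=O)cc2)cc1` gives 9030 nM there. Compound 2 `Cc1ccc(/C=C/C(=O)Oc2ccc(/C=C3\CCCC(CN(C)C)C3=O)cc2)cc1` gives 1290 nM, the lowest of the two numbers; its nearest neighbour, compound 1, sits beyond the scatter from it, but the two differ in more than one place, so no single step can be read between them. Compound 3 `COc1ccc(/C=C/C(=O)Oc2ccc(/C=C3\CCCC(CN(C)C)C3=O)cc2)cc1` is still unmeasured. It differs from compound 2 in one place: methoxy in place of methyl on an aromatic carbon. In this assay the step is expected to be a 1.2-fold higher number from compound 2 to compound 3 (0.07 log units; within the scatter), nothing beyond the scatter. Compound 3 is therefore estimated at 1500 nM, ranging from 600 nM to 4000 nM.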

Compound 3, half-maximal inhibitory concentration: 2410 nM
The estimate for compound 3 lay 1.6-fold (0.21 log units) below the measured number, within the range that was stated.
By their numbers in this assay, from the lowest: compounds 2 and 3 (each within the scatter of the next); then compound 1.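

Methoxy in place of methyl on this aromatic carbon gives a 1.9-fold higher number from compound 2 to compound 3 (0.27 log units; within the scatter) in this assay, so this change shows no clear effect at this position. The set now also holds a one-place comparison at the saturated ring carbon: (dimethylamino)methyl in place of hydrogen gives a 3.7-fold lower number from compound 1 to compound 3 (0.57 log units; beyond the scatter), a modest step. Nothing available explains either step.

On these data alone, how a hydroxyl group or a chlorine atom on that aromatic carbon would read stays open. So does whether a morpholine in place of the dimethylamino group would keep the step at the saturated ring carbon.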